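The source may report more compounds than this note shows. Statements on the series, on what has been measured and on what is new or still open speak of the compounds shown alone.

Of the compounds shown here, three have been measured in a functional assay on K562 cells (Homo sapiens) for antiproliferative activity, read by CellTiter-Glo and CCK-8 assay, with a stated time of 72 h; a lower number here means a stronger inhibitor of growth, a higher number a weaker inhibitor of growth. Compound 1 `Cc1ccc(Nc2ncc3c(n2)N(C)C(=O)N(c2cc(NC(=O)c4cccc(C(F)(F)F)c4)ccc2C)C3)cc1C` gives 17 nM. Compound 2 `CNc1nc(Nc2ccc(C)c([N+](=O)[O-])c2)ncc1C(=O)Nc1cc(NC(=O)c2cccc(C(F)(F)F)c2)ccc1C`, which shares the amide-linked benzamide side but has a different core, gives 52 nM. Compound 3 `CNc1nc(Nc2ccc(C)c([N+](=O)[O-])c2)ncc1C(=O)Nc1cc(NC(=O)c2ccc(OC)cc2)ccc1C` gives 1530 nM, the highest number of the three, so compound 3 is the weakest growth inhibitor in this set: its nearest neighbour in this assay is compound 2, and compound 1 lies furthest from it.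

Among the compounds with values here, the single measured step that touches the same part of the molecule is a 29-fold higher number from compound 2 to compound 3 (1.47 log units; beyond the scatter): swapping the group on the carbonyl carbon produced a large loss of potency.

Compound 4 `CNc1nc(Nc2ccc(C)c([N+](=O)[O-])c2)ncc1C(=O)Nc1cc(NC(=O)c2cc(OC)cc(OC)c2)ccc1C` differs from compound 3 by 3,5-dimethoxyphenyl in place of 4-methoxyphenyl on a carbonyl carbon. Within the data shown here, the earlier step shows that this carbonyl-attached ring matters, but no measured pair compares two methoxy-bearing rings, so the direction cannot be read directly. Since compound 2 sits at 52 nM with a substituent in the meta position and compound 3 at 1530 nM without one, a modest move back toward compound 2 is expected, with the step from compound 3 to compound 4 estimated as a 2.2-fold lower number from compound 3 to compound 4 (0.34 log units; beyond the scatter). Compound 4 is therefore expected to give about 700 nM in this assay, within a range from 200 nM to 2500 nM.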

Compound 4, concentration for 50% growth inhibition: 1070 nM
Estimate against measurement, compound 4: 1.5-fold (0.18 log units) below; the measured number falls inside the stated range.
By their numbers in this assay, from the lowest: compound 1; then compound 2; then compounds 4 and 3 (each within the scatter of the next).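

In this assay the change of ring on this carbonyl carbon gives a 1.4-fold lower number from compound 3 to compound 4 (0.16 log units; within the scatter), so 4-methoxyphenyl and 3,5-dimethoxyphenyl cannot be told apart here, although the second ring carries an extra methoxy group. The comparison with the better compound in the series gives a 21-fold higher number from compound 2 to compound 4 (1.31 log units; beyond the scatter), which means that 3,5-dimethoxyphenyl does not bring back what was lost when 3-(trifluoromethyl)phenyl left. Within the data shown here, the large loss at this position is therefore not peculiar to 4-methoxyphenyl: among the three rings now compared on this carbonyl carbon, both methoxy-bearing rings sit far from 3-(trifluoromethyl)phenyl, and the earlier compounds could show this for only one such ring.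

No measurement shown gives a reason for this difference between the rings. Still open, going by these compounds, is whether a phenyl ring bearing a chlorine or a nitrile, or a chain ending in an amine, would stay with the methoxy-bearing rings on this carbonyl carbon or come closer to compound 2.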